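The source may report more compounds than this note shows. Statements on the series, on what has been measured and on what is new or still open speak of the compounds shown alone.

Measured compounds in a functional assay on HT-29 cells (Homo sapiens) for antiproliferative activity; a lower number here means a stronger inhibitor of growth, a higher number a weaker inhibitor of growth:
compound 1 `c1ccc(-c2cc(-c3ccsc3)cc(-c3ccccn3)n2)nc1`, 0.0027 ug/mL
compound 2 `c1ccc(-c2cc(-c3ccsc3)cc(-c3cccnc3)n2)nc1`, 0.36 ug/mL
compound 3 `c1ccc(-c2cc(-c3cccs3)cc(-c3ccccn3)n2)nc1`, 0.0018 ug/mL

Compound 1 stands second highest of the three numbers; its nearest neighbour is compound 3, separated by a 1.5-fold lower number from compound 1 to compound 3 (0.18 log units; within the scatter), and its furthest is compound 2, separated by a 130-fold higher number from compound 1 to compound 2 (2.12 log units; beyond the scatter). The step to compound 2 is the only one beyond the scatter, and it concerns the pyridine attachment, not the five-membered ring.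

Compound 4 `c1ccc(-c2cc(-c3ccoc3)cc(-c3ccccn3)n2)nc1` is not yet measured. It differs from compound 1 as furan-3-yl in place of thiophen-3-yl on an aromatic carbon. The step that bears on this change is the one within the five-membered ring, a 1.5-fold lower number from compound 1 to compound 3 (0.18 log units; within the scatter), which lies within the scatter; exchanging one five-membered aromatic ring with one hetero atom for another of the same size therefore gave no movement worth the name in the one case available. The change to compound 4 again keeps the size and count of the ring, so no step beyond the scatter is expected, with at most a slight drift to a higher number.

For compound 4 the expected value in this assay is 0.004 ug/mL, with a range from 0.0015 ug/mL to 0.012 ug/mL, which amounts to an expected step of a 1.5-fold higher number from compound 1 to compound 4 (0.17 log units; within the scatter).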

Compound 4, concentration for 50% growth inhibition: 0.0026 ug/mL
The estimate for compound 4 lay 1.5-fold (0.19 log units) above the measured number; the measured number falls inside the stated range.
By their numbers in this assay, from the lowest: compounds 3, 4 and 1 (each within the scatter of the next); then compound 2.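

In this assay, furan-3-yl in place of thiophen-3-yl on the aromatic carbon opposite the ring nitrogen gives a 1.0-fold lower number from compound 1 to compound 4 (0.02 log units; within the scatter), so at this position the hetero atom of the five-membered ring can be exchanged, as well as its point of attachment, without a step beyond the scatter. Furan-3-yl in place of thiophen-2-yl, which changes hetero atom and attachment together, gives a 1.4-fold higher number from compound 3 to compound 4 (0.16 log units; within the scatter), so the three five-membered rings shown cannot be told apart in this assay. No measurement at hand accounts for this tolerance.

Every group shown at this position is a five-membered aromatic ring with one hetero atom, so it remains open how a phenyl ring, a morpholine or a longer alkyl chain would fare there. Also open, on these data alone, is whether furan-3-yl keeps pace with thiophen-3-yl when a pyridin-3-yl group replaces a pyridin-2-yl group, the change that gave a 130-fold higher number from compound 1 to compound 2 (2.12 log units; beyond the scatter).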